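The source may report more compounds than this note shows. Statements on the series, on what has been measured and on what is new or still open speak of the compounds shown alone.

Measured so far in a functional assay on CAKI-1 cells (Homo sapiens) for inhibition, read by sulforhodamine B assay, with a stated time of 48 h; on this read-out higher numbers stand for weaker inhibition of growth and lower numbers for stronger inhibition of growth:
compound 1 `Nc1cc(N)c2nc(-c3ccccc3)c(Oc3ccc(Cl)c(Cl)c3)nc2c1` gives 15800 nM
compound 2 `COc1cc(CNc2nc3cc(N)cc(N)c3nc2-c2ccccc2)cc(OC)c1OC` gives 1910 nM
compound 3 `COc1ccc(CNc2nc3cc(N)cc(N)c3nc2-c2ccccc2)cc1` gives 16200 nM

Compound 1 stands second highest of the three numbers. Its nearest neighbour is compound 3, whose number in this assay sits within the scatter of the number for compound 1, so the two cannot be told apart. Compound 2 is the furthest: its number in this assay is the lowest of the three and lies beyond the scatter from compound 1, so compound 2 inhibits growth more strongly than compound 1 on the values shown. Compounds 2 and 3 carry aminomethyl-linked groups on the shared core; compound 1 carries an aryloxy group instead.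

The step to compound 4 `Nc1cc(N)c2nc(-c3ccccc3)c(Sc3ccc(F)cc3)nc2c1` changes the group on compound 1: (4-fluorophenyl)sulfanyl in place of 3,4-dichlorophenoxy on an aromatic carbon. Among the measured compounds shown here, no measured pair in this assay shows a step of this kind, so no size can be read from the data. In the absence of such a step, the number for compound 4 is expected to stay close to that of compound 1, with no change beyond the scatter; the expected step is a 1.2-fold lower number from compound 1 to compound 4 (0.08 log units; within the scatter). Compound 4 is therefore estimated at 13000 nM, in the range 4000 nM to 40000 nM.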

Compound 4, concentration for 50% growth inhibition: < 100000 nM
Compound 4: no number, only a limit; the forecaster's own chance of this, stated with the estimate: 10%; the middle value does not contradict the limit.
By their numbers in this assay, from the lowest: compound 2; then compounds 1 and 3 (each within the scatter of the next).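

In this assay compound 4 gives < 100000 nM, which is a limit and not a number. No step from compound 1 to compound 4 can be read, because the only result for compound 4 is: the limit of < 100000 nM in this assay, at which 1 of the 4 values shown sits.

The compounds shown leave open whether (4-fluorophenyl)sulfanyl in place of 3,4-dichlorophenoxy on an aromatic carbon changes growth inhibition at all, and in which direction.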